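Chain Lengthening and Half-Life in One Compound Series

This account rests on a few compounds, and the source may have more. Where it says the series, first, only, none or still open, it means among the compounds named here.

Measured so far:
compound 1, `CCCCCCCCCNC(=O)Oc1ccc(Cl)cc1C(=O)Nc1cccc(Cl)c1`: 43 h
compound 2, `CCCCCCCCCCNC(=O)Oc1ccc(Cl)cc1C(=O)Nc1cccc(Cl)c1`: 43 h
compound 3, `CCCCCCCNC(=O)Oc1ccc(Cl)cc1C(=O)Nc1ccc(Cl)c(Cl)c1`: 43 h

In an ADME assay for metabolic stability, read by HPLC, at pH 7.4 (on this read-out higher numbers stand for a longer-lived compound and lower numbers for a shorter-lived compound), compound 1 gives 43 h. Compound 2 is built from the same core and differs from compound 1 by methyl in place of hydrogen on a saturated chain carbon, nine bonds along the chain from an amide-type nitrogen. This change left the read-out where it was: no change at the digits printed from compound 1 to compound 2 (within the scatter).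

Compound 3 carries a different core; the difference between its core and the core of compound 1 is not broken down here. In this assay compound 3 gives 43 h, a value level with those of compound 1 and compound 2 within the scatter of the method.

Compound 4, `CCCCCCCCNC(=O)Oc1ccc(Cl)cc1C(=O)Nc1ccc(Cl)c(Cl)c1`, is not yet measured. It differs from compound 3 by methyl in place of hydrogen on a saturated chain carbon, seven bonds along the chain from an amide-type nitrogen. This is the same kind of change as that from compound 1 to compound 2, but not the same: there the methyl entered nine bonds along the chain from an amide-type nitrogen, here it enters seven bonds along the chain from an amide-type nitrogen. The one measured case of this kind, no change at the digits printed from compound 1 to compound 2 (within the scatter), showed no movement, and nothing among the three measured compounds points to the chain length mattering for this read-out. Compound 4 is therefore expected to sit close to compound 3, a step estimated at no change at the digits printed from compound 3 to compound 4 (within the scatter). The estimate for compound 4 in this assay is 43 h, expected to lie between 25 h and 75 h.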

Compound 4, half-life: 43 h
Estimate against measurement, compound 4: no gap at the digits printed; measured number inside the range.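

In this assay the added methyl gave no change at the digits printed from compound 3 to compound 4 (within the scatter) and so behaved as it had on the core of compound 1: the same change on two cores in this assay, no change at the digits printed (within the scatter) from compound 1 to compound 2 and no change at the digits printed (within the scatter) from compound 3 to compound 4, 1.0-fold (0.00 log units) apart, within the scatter of two such steps. Across these two cores, then, the change carried over in the plain sense that lengthening the chain left the half-life unmoved in both cases, even though the methyl entered seven bonds along the chain from the amide-type nitrogen in one case and nine in the other. This does not show that the change is without effect on every core or at every chain length, since two steps that both show no movement say nothing about how a step that does move the read-out would carry from one core to another, and they give no reason for the agreement.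

The compounds shown leave open whether a much shorter chain, such as propyl or butyl, or a longer chain would hold the half-life at the same level. They also leave open whether a chain ending in an amine or a carboxylic acid, or a branched chain, would behave as these straight chains do on either core.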